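Hydroxy in place of methoxy on the aryl pyrazole series

The source may report more compounds than this note shows. Statements on the series, on what has been measured and on what is new or still open speak of the compounds shown alone.

Measured so far in a functional assay on HT-29 cells (Homo sapiens) for inhibition, read by sulforhodamine B assay, with a stated time of 48 h; on this read-out higher numbers stand for lower toxicity in this test and lower numbers for higher toxicity in this test:
compound 1, `COc1cc(C)cc(-c2nn(CC#N)cc2-c2ccc(-c3cccc(C(C)=O)c3)nc2)c1`: > 100000 nM
compound 2, `Cc1cc(O)cc(-c2nn(CC#N)cc2-c2ccnc(-c3ccc(Oc4ccccc4)cc3)c2)c1`: 8060 nM
compound 3, `COc1cc(C)cc(-c2nn(CC#N)cc2-c2ccnc(-c3ccc(N(C)C)cc3)c2)c1`: 37200 nM

The value for compound 1 in this assay is a limit of the assay, not a number; it is the case described by the limit of > 100000 nM in this assay, at which 1 of the 3 values shown sits. Of the two numbers, compound 3 gives the higher one, and compound 2 gives the lower; the gap between compound 3 and compound 2 lies beyond the scatter. Compound 2 and compound 3 differ in two places at once, so the two numbers alone do not separate the two changes.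

Compound 4, `Cc1cc(O)cc(-c2nn(CC#N)cc2-c2ccnc(-c3ccc(N(C)C)cc3)c2)c1`, is the next compound to be measured in this assay. It differs from compound 3 in one place: hydrogen in place of methyl on an oxygen on an aromatic ring, that is, methoxy becomes hydroxy, the 3-methoxy-5-methylphenyl becoming 3-hydroxy-5-methylphenyl, while the dimethylaminophenyl side of compound 3 is kept.

For the measured compounds named here, no measured pair shows this change on its own. The lower number of compound 2, 8060 nM, which carries the hydroxy, gives some reason to expect a step to a lower number for compound 4, but of modest size, since the other side of compound 2 also differs. The expected step is a 1.9-fold lower number from compound 3 to compound 4 (0.27 log units; within the scatter), toward higher toxicity in this test, possibly within the scatter.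

The estimate for compound 4 is therefore 20000 nM, with a range from 6000 nM to 70000 nM.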

Compound 4, concentration lethal to 50% of the cells: 93900 nM
Compound 4: the middle estimate sits 4.7-fold (0.67 log units) below what was measured, outside the stated range (above it).
By their numbers in this assay, from the lowest: compound 2; then compound 3; then compound 4. At a limit, above all of these: compound 1.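

In this assay, for the compounds shown here, hydrogen in place of methyl on an oxygen on an aromatic ring gives a 2.5-fold higher number from compound 3 to compound 4 (0.40 log units; beyond the scatter), toward lower toxicity in this test; with the dimethylaminophenyl side kept, this is the first reading of methoxy to hydroxy on its own, and its direction is opposite to what the hydroxy of compound 2 seemed to suggest. With the hydroxy kept, dimethylamino in place of phenoxy on an aromatic carbon gives a 12-fold higher number from compound 2 to compound 4 (1.07 log units; beyond the scatter), so the low number of compound 2 goes with its phenoxy side and not with its hydroxy. With compound 4 now high on the scale, little readable room remains above it, and compound 1 is a limit of the assay, not a number: the limit of > 100000 nM in this assay, at which 1 of the 4 values shown sits.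

Whether methoxy to hydroxy gives a step of the same direction and size on the phenoxy side remains open, as the single step shown comes from the dimethylaminophenyl side alone. Also open, from the compounds shown here alone, is how this position reads with an amine or a carboxylic acid in place of the hydroxy, or with a longer chain on the oxygen, such as ethoxy.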